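The source may hold more compounds than are shown below. What is called first, only, known or untested is meant among the compounds shown, and "the series" means these compounds.

Compound 1 `Cc1cc(=O)n(-c2ccc(F)cc2)nc1C(=O)Nc1ccc(Oc2ncnc3[nH]ccc23)cc1` gives in a functional assay on HepG2 cells (Homo sapiens) for cytotoxicity, read by MTT assay, with a stated time of 72 h (a higher number here means a weaker inhibitor, a lower number a stronger inhibitor), the value > 60000 nM, which is a limit of the assay and not a number.
Compound 2 `Cc1cc(=O)n(-c2cccc(F)c2)nc1C(=O)Nc1ccc(Oc2ncnc3[nH]ccc23)cc1` gives in this assay a value of 3180 nM.

Compound 2 thus holds the only number shown in this assay; the other value is a limit. Compound 3 `Cc1ccc(-n2nc(C(=O)Nc3ccc(Oc4ncnc5[nH]ccc45)cc3)c(C)cc2=O)cc1` differs from compound 2 by 4-methylphenyl in place of 3-fluorophenyl on an aromatic nitrogen. Going by the values given here, the one measured step at this aromatic nitrogen, an at least 18-fold lower number from compound 1 to compound 2 (1.27 log units; beyond the scatter), shows that the aryl group there matters greatly. Compound 1, which carries 4-fluorophenyl, sits at the limit of > 60000 nM in this assay, at which 1 of the 2 values shown sits. Compound 3 is therefore expected to give a higher number, a step of a 6.3-fold higher number from compound 2 to compound 3 (0.80 log units; beyond the scatter). The estimate for compound 3 is 20000 nM, between 4000 nM and 60000 nM.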

Compound 3, half-maximal inhibitory concentration: 7460 nM
The estimate for compound 3 lay 2.7-fold (0.43 log units) above the measured number; the range from low to high includes it.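

Compound 3 shows that 4-methylphenyl, unlike 4-fluorophenyl, still gives a measured number, and the change from 3-fluorophenyl is only a 2.3-fold higher number from compound 2 to compound 3 (0.37 log units; beyond the scatter). Methyl in place of fluoro on an aromatic carbon gives an at least 8.0-fold lower number from compound 1 to compound 3 (0.90 log units; beyond the scatter), so with the place on the ring unchanged, the group itself decides the outcome. Compound 1 holds a limit and not a number: the limit of > 60000 nM in this assay, at which 1 of the 3 values shown sits.

From the compounds shown here alone, it remains open how 3-methylphenyl would compare with 3-fluorophenyl. Going by these compounds, it is also open whether a methoxy group or an amine on this phenyl ring would follow methyl or fluoro.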